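Compound 2 to compound 3: exchanging the ring on the chain

The compounds below may be only part of what the source reports. "The series", "measured", "known", "first", "only" and "open" are said of these compounds alone.

For the measured compounds named here, in an ADME assay on microsomes from liver (Mus musculus) for metabolic stability (a lower number here means that the compound disappears faster, a higher number that the compound lasts longer), compound 2 `Cc1nc(C(c2ccc(-c3ccc4cccc(F)c4c3)[nH]c2=O)C(C)C)[nH]c1C` gives 0.0817 h, the only actual number so far. Compound 1 `CC(C)C(Cc1ncc[nH]1)c1ccc(-c2ccc3cccc(F)c3c2)[nH]c1=O` stands at a limit, < 0.0667 h.

Compound 3 `CC(C)C(c1nnc[nH]1)c1ccc(-c2ccc3cccc(F)c3c2)[nH]c1=O` carries 4H-1,2,4-triazol-3-yl in place of 4,5-dimethyl-1H-imidazol-2-yl on a saturated chain carbon bound to an aromatic carbon and a saturated chain carbon.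

Going by the values given here, the one measured step bearing on this is an at least 1.2-fold higher number from compound 1 to compound 2 (0.08 log units; that floor lies within the scatter), a different exchange at the same place, and it sets no direction. The expected step of a 1.2-fold higher number from compound 2 to compound 3 (0.09 log units; within the scatter) therefore stays within the scatter. Compound 3 is estimated at 0.1 h, with an expected range of 0.06 h to 0.22 h.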

Compound 3, half-life: 0.213 h
Compound 3: middle estimate off by 2.1-fold (0.33 log units), on the low side; low and high end bracket the measured number.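

In this assay, the ring on the saturated chain carbon now gives a step beyond the scatter: 4H-1,2,4-triazol-3-yl in place of 4,5-dimethyl-1H-imidazol-2-yl gives a 2.6-fold higher number from compound 2 to compound 3 (0.42 log units; beyond the scatter) and so sets a direction at this position. Against (1H-imidazol-2-yl)methyl, the same group gives an at least 3.1-fold higher number from compound 1 to compound 3 (0.50 log units; beyond the scatter) as well. That second step is a floor and not a size: the limit of < 0.0667 h in this assay, at which 1 of the 3 values shown sits.

The step from 4,5-dimethyl-1H-imidazol-2-yl changes the ring nitrogens and removes the methyl groups together, and the compounds shown do not separate the two. From the compounds shown here alone, whether a carboxylic acid or an amine on this carbon would keep the higher number stays open.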